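The source may hold more compounds than are shown below. What is called first, only, known or untested is meant among the compounds shown, and "the series" means these compounds.

Of the compounds shown here, two have so far been measured in a functional assay on PC-3 cells (Homo sapiens) for cytotoxicity, read by MTT assay, with a stated time of 48 h; a lower number here means a stronger inhibitor, a higher number a weaker inhibitor. Compound 1 `CC1=NN(C(=O)CN2CCC(Cl)CC2)C(c2ccccc2O)C1` gives 34800 nM in this assay. Compound 2 `O=C(c1ccccc1)N1N=C(c2cc3ccccc3oc2=O)CC1c1ccccc1` gives 5870 nM in this assay, the lower of the two numbers, and the gap between the two lies beyond the usual scatter of repeated measurements.

Compound 3 `CCN(CC)C1CCN(CC(=O)N2N=C(c3cc4ccccc4oc3=O)CC2c2ccccc2)CC1` is not yet measured. It differs from compound 2 in one place: (4-(diethylamino)piperidin-1-yl)methyl in place of phenyl on a carbonyl carbon. Within the data shown here, no step between two measured compounds matches this change, so there is nothing to rest a firm direction on. The step from compound 2 to compound 3 in this assay is therefore expected to be small and most likely not to reach beyond the scatter, written here as a 1.4-fold higher number from compound 2 to compound 3 (0.13 log units; within the scatter). For compound 3 the expected value in this assay is 8000 nM, with a likely range from 2000 nM to 30000 nM.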

Compound 3, half-maximal inhibitory concentration: 26100 nM
For compound 3 the middle estimate is 3.3-fold (0.51 log units) below the measured one, and the stated range covers the measured number.
By their numbers in this assay, from the lowest: compound 2; then compounds 3 and 1 (each within the scatter of the next).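

In this assay, the group on the carbonyl carbon clearly matters: putting (4-(diethylamino)piperidin-1-yl)methyl in place of phenyl gives a 4.4-fold higher number from compound 2 to compound 3 (0.65 log units; beyond the scatter), a step toward weaker inhibition. Among these compounds, this is the first comparison here of two compounds that differ in one place, so it is the first direct reading of any change at this position, and it shows that the larger group with 12 heavy atoms and 2 hydrogen-bond acceptors does not match phenyl in this assay. Nothing measured here explains the step.

This single step cannot show which part of the exchange counts: the lost aromatic ring, the added size or the added nitrogens. It also leaves open whether a plain piperidine without the diethylamino group, or a phenyl carrying a methoxy group, would fall nearer to compound 2 or to compound 3.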